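Dropping the acetamido group from the phenylethyl amine

A few compounds are considered here, and "the series" means these few. Any claim that something is new, unique, unknown or untested is made for them only; others in the source may bear on it.

Measured so far in an assay on CHO cells for displacement of a labelled ligand from 5-hydroxytryptamine receptor 1D (Homo sapiens); on this read-out lower numbers stand for stronger inhibition and higher numbers for weaker inhibition:
- compound 1, `CN(Cc1ccsc1)C1CCN(CCCc2c[nH]c3ccc(-n4cnnc4)cc23)CC1`: 1.5 nM
- compound 2, `CC(=O)Nc1ccc([C@@H](C)NCC2CCN(CCCc3c[nH]c4ccc(-n5cnnc5)cc34)CC2)cc1`: 1.5 nM

Compound 2 stands level with compound 1 at the digits shown; the two values lie within the scatter of each other. Compound 3, `C[C@H](NCC1CCN(CCCc2c[nH]c3ccc(-n4cnnc4)cc23)CC1)c1ccccc1`, differs from compound 2 by 1-phenylethyl in place of 1-(4-acetamidophenyl)ethyl on an amine nitrogen. Among the compounds with values here, no measured pair isolates this change, so its effect is unknown. Since the shared core stays intact, the expected step is a 2.0-fold higher number from compound 2 to compound 3 (0.30 log units; within the scatter), a small weakening not clearly beyond the scatter. Compound 3 is estimated at 3 nM, with a range from 1 nM to 12 nM.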

Compound 3, half-maximal inhibitory concentration: 4.4 nM
Compound 3: middle estimate off by 1.5-fold (0.17 log units), on the low side; measured number inside the range.
By their numbers in this assay, from the lowest: compounds 1 and 2 (each within the scatter of the next); then compound 3.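

In this assay, 1-phenylethyl in place of 1-(4-acetamidophenyl)ethyl on the amine nitrogen gives a 2.9-fold higher number from compound 2 to compound 3 (0.47 log units; beyond the scatter) and so opens the first gap beyond the scatter in the series. The acetamido group therefore contributes only modestly at this position, and binding largely survives its loss. Compound 3 also lies apart from compound 1, with a 2.9-fold higher number from compound 1 to compound 3 (0.47 log units; beyond the scatter) for the change on the saturated ring carbon. Nothing available explains these steps.

On these data alone, whether an amine or a methoxy group in place of the acetamido group would restore the value of compound 2 remains open. So does the effect of the opposite configuration at the defined stereocentre.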